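Chloro to bromo on the 4-chlorophenyl group

A few compounds are considered here, and "the series" means these few. Any claim that something is new, unique, unknown or untested is made for them only; others in the source may bear on it.

Compound 3 `O=C(/C=C/c1ccc(Br)cc1)NS(=O)(=O)c1ccc(Cl)cc1` gives 5.2 ug/mL in a functional assay on B16-F10 cells (Mus musculus) for antiproliferative activity, read by ELISA and MTT assay, with a stated time of 48 h (on this read-out lower numbers stand for stronger inhibition and higher numbers for weaker inhibition), the second highest of the three numbers. Compound 1 `O=C(/C=C/c1ccc(Cl)cc1)NS(=O)(=O)c1ccc(Br)cc1` gives 2.8 ug/mL, within the scatter of compound 3, while compound 2 `Cc1ccc(S(=O)(=O)NC(=O)/C=C/c2ccc(Br)cc2)cc1` gives 12.1 ug/mL, and the step of a 2.3-fold lower number from compound 2 to compound 3 (0.37 log units; beyond the scatter) lies beyond the scatter. Compound 4 `O=C(/C=C/c1ccc(Br)cc1)NS(=O)(=O)c1ccc(Br)cc1` differs from compound 3 by bromo in place of chloro on an aromatic carbon. Among the measured compounds shown here, no measured step exchanges chloro for bromo at this place; the single measured step, a 2.3-fold lower number from compound 2 to compound 3 (0.37 log units; beyond the scatter), concerns methyl to chloro and bears only loosely. Compounds 1 and 3, which carry the two halogens in swapped places, give numbers within the scatter of each other. Therefore no step beyond the scatter is expected, a 1.5-fold lower number from compound 3 to compound 4 (0.17 log units; within the scatter). Compound 4 is estimated at 3.5 ug/mL, with a range of 1.5 ug/mL to 8 ug/mL.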

Compound 4, half-maximal inhibitory concentration: 5.1 ug/mL
Compound 4: middle estimate off by 1.5-fold (0.16 log units), on the low side; low and high end bracket the measured number.
By their numbers in this assay, from the lowest: compounds 1, 4 and 3 (each within the scatter of the next); then compound 2.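

In this assay, chloro and bromo are now compared directly at this place, on an aromatic carbon para to a large group, and the exchange stays within the scatter (a 1.0-fold lower number from compound 3 to compound 4 (0.01 log units; within the scatter)). The same halogen exchange at the other halogen-bearing place also stays within the scatter (a 1.8-fold higher number from compound 1 to compound 4 (0.26 log units; within the scatter)), whereas methyl to bromo lies beyond it (a 2.4-fold lower number from compound 2 to compound 4 (0.38 log units; beyond the scatter)), so both halogens at this place separate from methyl. Nothing available bears on the cause of these steps.

Going by these compounds, whether fluoro, methoxy or an amine at this place would group with the halogens or with methyl remains open.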